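Bromo on the fused ring of compound 2

The source may report more compounds than this note shows. Statements on the series, on what has been measured and on what is new or still open speak of the compounds shown alone.

Measured compounds:
compound 1 `Cc1cc(Nc2nc(NCc3ccc(Cl)cc3)nc3ccccc23)n[nH]1` 380 nM
compound 2 `Cc1cc(Nc2nc(NCc3ccc(F)cc3F)nc3ccccc23)n[nH]1` 200 nM

In an assay for inhibition of high affinity nerve growth factor receptor (Homo sapiens), read by HTRF, with a stated time of 30 min, in the presence of a further agent that is not named here (on this read-out lower numbers stand for stronger inhibition and higher numbers for weaker inhibition), compound 1 gives 380 nM. Compound 2 gives 200 nM. Among the measured compounds shown here, the single step between them, a 1.9-fold lower number from compound 1 to compound 2 (0.28 log units; within the scatter), is within the scatter, so the two numbers are not separated. Compound 2 stands at the lower-placed number of the two, but only by a gap within the scatter.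

Compound 3 `Cc1cc(Nc2nc(NCc3ccc(F)cc3F)nc3cc(Br)ccc23)n[nH]1` differs from compound 2 by bromo in place of hydrogen on an aromatic carbon. For the measured compounds named here, no measured step touches this ring: the step from compound 1 to compound 2 concerns the benzylic aryl group, not the fused ring, so it does not bear on the change. Going by the values given here, with no step to draw on, no movement beyond the scatter is expected in this assay, and the expected step is no change at the digits printed from compound 2 to compound 3 (within the scatter). The estimate for compound 3 is 200 nM, with a range of 60 nM to 700 nM.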

Compound 3, half-maximal inhibitory concentration: 53 nM
Beside the measured number, compound 3's estimate is 3.8-fold (0.58 log units) above it; the measured number lies below the stated range.
By their numbers in this assay, from the lowest: compound 3; then compounds 2 and 1 (each within the scatter of the next).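

In this assay, bromo in place of hydrogen on this aromatic carbon of the fused system gives a 3.8-fold lower number from compound 2 to compound 3 (0.58 log units; beyond the scatter), a modest step. Among the compounds shown here, this is the first step to lie beyond the scatter, and it shows that this position on the shared core can move the number, while the change of aryl group between compound 1 and compound 2 does not separate those two compounds. No measurement shown here accounts for the step.

On these data alone, it remains open whether the step is specific to bromo or would also appear with chloro, methyl, methoxy or an amine on the same carbon. Also open, as far as these compounds go, is whether bromo at this position would give a similar step with the 4-chlorophenyl group of compound 1.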